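Shifting Two Fluorines: What to Expect for Compound 4

The source may report more compounds than this note shows. Statements on the series, on what has been measured and on what is new or still open speak of the compounds shown alone.

Measured in an ADME assay on MT4 cells (Homo sapiens) for cytotoxicity, read by MTT assay; on this read-out lower numbers stand for higher toxicity in this test and higher numbers for lower toxicity in this test:
- compound 1 `Cc1ccc(C(=O)N(C(=S)OCCN2C(=O)c3ccccc3C2=O)c2ccc(Cl)cc2)cc1`: > 100000 nM (a limit of the assay)
- compound 2 `O=C1c2ccccc2C(=O)N1CCOC(=S)N(C(=O)c1ccc(C(F)(F)F)cc1)c1ccc(Cl)cc1`: 10000 nM
- compound 3 `O=C1c2ccccc2C(=O)N1CCOC(=S)N(C(=O)c1ccc(F)cc1F)c1ccc(Cl)cc1`: 52000 nM

Compound 1 gives > 100000 nM, which is a limit of the assay and not a number. Of the two exact numbers, compound 3 holds the higher one, and the gap to its nearest neighbour is a 5.2-fold higher number from compound 2 to compound 3 (0.72 log units; beyond the scatter).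

The next structure is compound 4 `O=C1c2ccccc2C(=O)N1CCOC(=S)N(C(=O)c1cc(F)cc(F)c1)c1ccc(Cl)cc1`. Its change is 3,5-difluorophenyl in place of 2,4-difluorophenyl on a carbonyl carbon. The atoms stay the same and only their arrangement differs.

Within the data shown here, no measured step shifts fluorines alone. The closest guide swaps a whole group on that carbonyl carbon, giving a 5.2-fold higher number from compound 2 to compound 3 (0.72 log units; beyond the scatter). Another such swap gives an at least 1.9-fold lower number from compound 1 to compound 3 (0.28 log units; that floor lies within the scatter). A further change, on the aromatic carbon, gives an at least 10-fold lower number from compound 1 to compound 2 (1.00 log units; beyond the scatter). These steps replace different groups, so a smaller effect is expected from this rearrangement, with no clear direction. The estimated step is a 1.2-fold lower number from compound 3 to compound 4 (0.06 log units; within the scatter), so none beyond the scatter is expected. For compound 4 the estimate is 45000 nM, with an expected range of 18000 nM to 100000 nM.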

Compound 4, half-maximal cytotoxic concentration: 59000 nM
For compound 4 the middle estimate is 1.3-fold (0.12 log units) below the measured one; measured number inside the range.
By their numbers in this assay, from the lowest: compound 2; then compounds 3 and 4 (each within the scatter of the next). At a limit, above all of these: compound 1.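

Moving the two fluorines, with 3,5-difluorophenyl in place of 2,4-difluorophenyl on a carbonyl carbon, gives a 1.1-fold higher number from compound 3 to compound 4 (0.05 log units; within the scatter) in this assay, so this rearrangement alone leaves no change that can be told from scatter, which the earlier swaps of whole groups could not show. The separation from the trifluoromethyl compound also holds for the new arrangement, with a 5.9-fold higher number from compound 2 to compound 4 (0.77 log units; beyond the scatter) as its step. Compound 1 holds a limit of the assay and not a number, so an at least 1.6-fold lower number from compound 1 to compound 4 (0.22 log units; that floor lies within the scatter) is only a floor and gives no true size: the limit of > 100000 nM in this assay, at which 1 of the 4 values shown sits.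

Going by these compounds, what a methoxy group, a nitrile or an amine would do on this ring stays open. So does whether a single fluorine or 2,6-difluorophenyl would behave like the two difluorophenyl groups shown.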